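A few compounds are considered here, and "the series" means these few. Any claim that something is new, unique, unknown or untested is made for them only; others in the source may bear on it.

Measured compounds:
Compound 1, `COc1cc(C)cc(-c2nn(CC#N)cc2-c2ccc(-c3cccc(C(C)=O)c3)nc2)c1`: > 100000 nM in a functional assay on SNB-19 cells (Homo sapiens) for inhibition, read by sulforhodamine B assay, with a stated time of 48 h; a higher number here means that more compound is tolerated, a lower number that less compound is tolerated.
Compound 2, `Cc1cc(O)cc(-c2nn(CC#N)cc2-c2ccnc(-c3ccc(Oc4ccccc4)cc3)c2)c1`: 51100 nM in this assay .

In this assay the value of compound 1 is a limit, not a number (the limit of > 100000 nM in this assay, at which 1 of the 2 values shown sits). Compound 2 therefore supplies the only number shown in this assay. Compound 3, `Cc1cc(O)cc(-c2nn(CC#N)cc2-c2ccnc(-c3ccc(N(C)C)cc3)c2)c1`, has not been measured; it differs from compound 2 by dimethylamino in place of phenoxy on an aromatic carbon. Going by the values given here, no measured pair tracks this change, so no step size is known from the data. The step of a 1.2-fold higher number from compound 2 to compound 3 (0.07 log units; within the scatter) is expected to stay within the scatter. Compound 3 is expected to give 60000 nM in this assay, with a range from 20000 nM to 150000 nM.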

Compound 3, concentration lethal to 50% of the cells: > 100000 nM
Compound 3 was reported as a limit (the forecaster's own chance of this, stated with the estimate: 35%); middle value at least 1.6-fold (0.22 log units) from the limit.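

Dimethylamino in place of phenoxy on an aromatic carbon gives the first step at this position in this assay: an at least 1.9-fold higher number from compound 2 to compound 3 (0.29 log units; that floor lies within the scatter). Only a floor is known for this step, and it lies within the scatter, so the true size of the change remains unread. The value of compound 3 is a limit, not a number: the limit of > 100000 nM in this assay, at which 2 of the 3 values shown sit.

As far as these compounds go, how far the step extends beyond its floor stays open. Also open, from the compounds shown here alone, is what a primary amine or a carboxylic acid would give on this aromatic carbon.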